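Pyridone series: amide swap at the aryl ether pyridine

The source may report more compounds than this note shows. Statements on the series, on what has been measured and on what is new or still open speak of the compounds shown alone.

Measured compounds in a functional assay on MKN-45 cells (Homo sapiens) for antiproliferative activity, read by MTT assay, with a stated time of 72 h, tested at 10 uM; on this read-out lower numbers stand for less inhibition and higher numbers for more inhibition at the one concentration tested (going by the name of the read-out):
- compound 1 `Cn1cc(-c2ccc(F)cc2)c(=O)c2c(Nc3ccc(Oc4ccnc(NC(=O)C5CC5)c4)c(F)c3)nccc21`: 30.9%
- compound 2 `CC(=O)Nc1cc(Oc2ccc(Nc3nccc4[nH]cc(-c5ccc(F)cc5)c(=O)c34)cc2F)ccn1`: 77.1%
- compound 3 `Nc1nccc(Oc2ccc(Nc3nccc4[nH]cc(-c5ccc(F)cc5)c(=O)c34)cc2F)c1Cl`: 85.7%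

Compound 3 gives the highest of the three numbers in this assay. Its nearest neighbour is compound 2, with the step of a number 8.6 percentage points higher from compound 2 to compound 3 (within the scatter) lying within the scatter, so the two cannot be ordered. Compound 1, which carries a methyl on the core nitrogen where compounds 2 and 3 carry a hydrogen, sits far lower, and that gap is beyond the scatter.

The next compound, compound 4 `O=C(Nc1cc(Oc2ccc(Nc3nccc4[nH]cc(-c5ccc(F)cc5)c(=O)c34)cc2F)ccn1)C1CC1`, differs from compound 3 only at the pyridine on the ether oxygen: 2-((cyclopropylcarbonyl)amino)pyridin-4-yl in place of 2-amino-3-chloropyridin-4-yl on an oxygen on an aromatic ring. Going by the values given here, the single measured step that bears on this position is the one from compound 2 to compound 3, an exchange of an acetamide for an amino-chloro pattern at the same place, and it stayed within the scatter. Among the compounds with values here, compound 1 has the same cyclopropylcarbonylamino pyridine as compound 4 but a different core, so its value shows only that this group is compatible with a low number on another scaffold. Within the data shown here, no step connects the two cores.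

On this basis the expected step of a number 11.7 percentage points lower from compound 3 to compound 4 (beyond the scatter) is small, none beyond the scatter. Compound 4 is estimated at 74% in this assay, in the range 52% to 90%.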

Compound 4, a percentage reported as inhibition, at one concentration (the size of the read-out at that concentration, not a potency): 81.8%
Compound 4: the middle estimate sits 7.8 percentage points below what was measured, and the stated range covers the measured number.
By their numbers in this assay, from the lowest: compound 1; then compounds 2, 4 and 3 (each within the scatter of the next).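

Read in this assay, the pyridine on the ether oxygen now has three variants that cannot be ordered: the exchange of the amino-chloro pattern for the cyclopropyl amide gives a number 3.9 percentage points lower from compound 3 to compound 4 (within the scatter) and the exchange of methyl for cyclopropyl on the carbonyl carbon gives a number 4.7 percentage points higher from compound 2 to compound 4 (within the scatter) in this comparison. The 2-((cyclopropylcarbonyl)amino)pyridin-4-yl group therefore goes with a high number on the core bearing hydrogen on the aromatic nitrogen, although the same group gave a low number on the core of compound 1. The pair that differs in one place gives a number 50.9 percentage points higher from compound 1 to compound 4 (beyond the scatter) with hydrogen in place of methyl on that aromatic nitrogen, so the large gap, earlier seen only across compounds differing in two places, now rests on this single change; no measurement at hand explains the size of any of these steps.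

Open, on these data alone, is how an ethyl group on the aromatic nitrogen would compare with hydrogen and methyl. Also open, as far as these compounds go, is whether a benzoyl amide or a plain 2-aminopyridin-4-yl group at the ether oxygen would stay level with compound 2, compound 3 and compound 4 in this assay at the single concentration tested.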